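Methoxy walk on the enone series, cytotoxicity on DU-145 cells

The source may report more compounds than this note shows. Statements on the series, on what has been measured and on what is new or still open speak of the compounds shown alone.

Compound 1 `COc1ccc(/C=C/C(=O)/C=C/c2cc3ccccc3nc2Cl)cc1` carries one methoxy group on its aryl ring. In a functional assay on DU-145 cells (Homo sapiens) for cytotoxicity, read by MTT assay, with a stated time of 48 h (a higher number here means a weaker inhibitor, a lower number a stronger inhibitor), compound 1 gives > 10000 nM, which is a limit of the assay and not a number. Compound 2 `COc1ccc(/C=C/C(=O)/C=C/c2cc3ccccc3nc2Cl)c(OC)c1` differs by methoxy in place of hydrogen on an aromatic carbon. In this assay compound 2 gives > 10000 nM, again a limit and not a number. The step that the two limits leave unreadable from compound 1 to compound 2 therefore cannot be read. Compound 3 `COc1ccc(/C=C/C(=O)/C=C/c2cc3ccccc3nc2Oc2ccccc2)cc1OC` has a different core from compound 1; the difference between the two cores is not broken down here. In this assay compound 3 gives > 10000 nM, likewise a limit. Compound 4 `COc1cc(OC)c(OC)cc1/C=C/C(=O)/C=C/c1cc2ccccc2nc1Oc1ccccc1` is not yet measured and differs from compound 3 by methoxy in place of hydrogen on an aromatic carbon; this is the same kind of change as from compound 1 to compound 2, though here the entering group is also para to a methoxy group. Going by the values given here, the only evidence on the change so far is the limit of > 10000 nM in this assay, at which 3 of the 3 values shown sit. Because of the limit of > 10000 nM in this assay, at which 3 of the 3 values shown sit, compound 4 is expected to stay at the limit, estimated at 15000 nM, with a range from 7000 nM to 40000 nM. The expected step that the limit leaves unreadable from compound 3 to compound 4 is thus essentially nil.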

Compound 4, half-maximal inhibitory concentration: 9220 nM
Beside the measured number, compound 4's estimate is 1.6-fold (0.21 log units) above it, and the stated range covers the measured number.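

On the core of compound 3, this assay reads the methoxy change as an at least 1.0-fold lower number from compound 3 to compound 4 (0.03 log units; that floor lies within the scatter), which is a floor and not a measured size, so the change is not shown to move the value beyond the scatter. The matching step on the core of compound 1 cannot be read, so nothing shows that the change carries from one core to the other in either size or direction, and in compound 4 the entering group also sits para to a methoxy group. Any reading of the change remains tied to the assay limit: the limit of > 10000 nM in this assay, at which 3 of the 4 values shown sit.

Open, from the compounds shown here alone, is whether the methoxy change has a readable size on a pair of compounds that both give numbers clear of the limit. Also open, going by these compounds, is how an amine or a carboxylic acid on the aryl ring, in place of a methoxy group, would read in this assay.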